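Cytotoxicity limits for three compounds and a fourth to come

The compounds below may be only part of what the source reports. "The series", "measured", "known", "first", "only" and "open" are said of these compounds alone.

Compound 1 `CCOC(=O)c1c(-c2cccc(OC)c2)[nH]c2cc(OC)c(OC)cc2c1=O`: > 21500 nM
Compound 2 `CCOC(=O)c1c(-c2cccc(OC)c2)[nH]c2cc(Cl)c(OC)cc2c1=O`: > 21500 nM
Compound 3 `CCOC(=O)c1c(-c2cccc(-c3ccccc3)c2)[nH]c2cc(Cl)c(Cl)cc2c1=O`: > 21500 nM

In an ADME assay on HepG2 cells (Homo sapiens) for cytotoxicity, read by luminescence, with a stated time of 72 h (a higher number here means that more compound is needed for the effect, a lower number that less compound is needed), compound 1 gives > 21500 nM, which is a limit of the assay and not a number. Compound 2 likewise gives > 21500 nM, a limit. Compound 3 gives > 21500 nM, again a limit. (the limit of > 21500 nM in this assay, at which 3 of the 3 values shown sit). The change from compound 2 to compound 1 is methoxy in place of chloro on an aromatic carbon and gives a step that the two limits leave unreadable from compound 2 to compound 1. The cores of compound 2 and compound 3 differ, but that difference is not broken down here.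

Compound 4 `CCOC(=O)c1c(-c2cccc(-c3ccccc3)c2)[nH]c2cc(OC)c(Cl)cc2c1=O` differs from compound 3 by methoxy in place of chloro on an aromatic carbon. This is the same kind of change as from compound 2 to compound 1, though there the entering group sits ortho to a methoxy group (2 heavy atoms), here ortho to a chloro group (1 heavy atom). Because (the limit of > 21500 nM in this assay, at which 3 of the 3 values shown sit), compound 4 is expected to stay at or beyond that limit, around 40000 nM, a step that the limit leaves unreadable from compound 3 to compound 4 from compound 3, with an estimated range of 21500 nM to 100000 nM.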

Compound 4, half-maximal effective concentration: > 21500 nM
Compound 4: only a limit was reported (the forecaster's own chance of this, stated with the estimate: 85%); the middle value is on the limit's open side.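

For the compounds shown here, the reading for compound 4 is a limit, as is that for compound 3, so no step between compound 3 and compound 4 can be read: the limit of > 21500 nM in this assay, at which 4 of the 4 values shown sit. The compounds shown leave open what concentration any of them needs for the effect, and whether methoxy in place of chloro changes it.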